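A few compounds are considered here, and "the series" means these few. Any claim that something is new, unique, unknown or untested is made for them only; others in the source may bear on it.

Measured so far:
- compound 1 `Cc1cnc(NC(=O)CSc2nncnc2-c2ccccc2Cl)c(Br)c1`: 144000 nM
- compound 2 `O=C(CSc1nncnc1-c1ccccc1Cl)Nc1ccccc1F`: 98000 nM

In an ADME assay on MT4 cells (Homo sapiens) for cytotoxicity, read by MTT assay (on this read-out lower numbers stand for higher toxicity in this test and higher numbers for lower toxicity in this test), compound 2 gives 98000 nM, within the scatter of compound 1 at 144000 nM. These two numbers are all that the series offers so far.

Compound 3 `O=C(CSc1nncnc1-c1ccccc1Cl)Nc1cccnc1Cl` is the next case. The change is 2-chloropyridin-3-yl in place of 2-fluorophenyl on an amide-type nitrogen.

Among the measured compounds shown here, one measured step bears on it, as it also exchanges the group at this place: a 1.5-fold lower number from compound 1 to compound 2 (0.17 log units; within the scatter). That step stays within the scatter, and a single step is thin evidence. From the compounds shown here alone, no step beyond the scatter is therefore expected in this assay, and the direction stays open. The expected change is small: a 1.1-fold higher number from compound 2 to compound 3 (0.05 log units; within the scatter). For compound 3 the estimated value is 110000 nM, with an expected range from 50000 nM to 230000 nM.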

Compound 3, half-maximal cytotoxic concentration: 167000 nM
Compound 3: the middle estimate sits 1.5-fold (0.18 log units) below what was measured, within the range that was stated.
By their numbers in this assay, from the lowest: compounds 2, 1 and 3 (each within the scatter of the next).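

In this assay, the exchange of 2-fluorophenyl for 2-chloropyridin-3-yl on an amide-type nitrogen stays within the scatter (a 1.7-fold higher number from compound 2 to compound 3 (0.23 log units; within the scatter)), as does the exchange of 3-bromo-5-methylpyridin-2-yl for 2-chloropyridin-3-yl (a 1.2-fold higher number from compound 1 to compound 3 (0.06 log units; within the scatter)). Three groups at this place now read within the scatter of one another, and a group with one hydrogen-bond acceptor replaces one with none without a step beyond it. No available measurement accounts for the small differences that remain.

From the compounds shown here alone, whether an amine, a carboxylic acid or a longer chain on this nitrogen would stay in the same range remains open. Going by these compounds, the shared core is the same in all three compounds, so how the read-out responds to changes elsewhere also remains open.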